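Trifluoromethoxy in place of fluoro on the core of compound 2

A few compounds are considered here, and "the series" means these few. Any claim that something is new, unique, unknown or untested is made for them only; others in the source may bear on it.

Measured so far:
compound 1, `Cn1c(C(=O)Cc2cccnc2)cc2ccccc21`: "not active" (no number reported)
compound 2, `O=C(Cc1cccnc1)c1cc2cc(F)ccc2[nH]1`: 24%

Two compounds have been examined so far in an in vitro assay on P815B cells for inhibition of Indoleamine 2,3-dioxygenase 1 (Mus musculus), tested at 20 uM; a lower number here means less inhibition, a higher number more inhibition at the concentration tested (going by the name of the read-out). Compound 1, `Cn1c(C(=O)Cc2cccnc2)cc2ccccc21`, was reported in this assay as "not active" (no number reported), with no number given. Compound 2, `O=C(Cc1cccnc1)c1cc2cc(F)ccc2[nH]1`, is the only compound with a figure in this assay, where compound 2 gives 24%; it therefore stands alone on the numbers shown, and nothing can be said about its place among others.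

Compound 3, `O=C(Cc1cccnc1)c1cc2cc(OC(F)(F)F)ccc2[nH]1`, has not yet been tested. It differs from compound 2 in one place: trifluoromethoxy in place of fluoro on an aromatic carbon. The change sits on an aromatic carbon of a six-membered aromatic ring of carbon only, part of a fused or bridged system of two rings. Going by the values given here, no step between measured compounds of this kind is available, so there is no basis for expecting more than a small shift in this assay, in either direction, and most likely none beyond the scatter. The expected step from compound 2 to compound 3 is a number 1 percentage points higher from compound 2 to compound 3 (within the scatter). Compound 3 is estimated to give 25% in this assay, within a range of 5% to 50%.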

Compound 3, a percentage reported as inhibition, at one concentration (the size of the read-out at that concentration, not a potency): 12%
The estimate for compound 3 lay 13 percentage points above the measured number; low and high end bracket the measured number.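

In this assay, the replacement of fluoro by trifluoromethoxy gives a number 12 percentage points lower from compound 2 to compound 3 (beyond the scatter), the first indication that the read-out responds to what sits on this aromatic carbon, meta to a fused ring and para to a fused ring. The step is modest, and compound 3 still gives 12%, so this change lowers the inhibition without removing it at the concentration tested. Nothing measured on these compounds accounts for the step, which therefore stands as an observation without an explanation.

With one step at this position, the compounds shown leave open whether the lower number goes with the 5 heavy atoms of trifluoromethoxy, against 1 for fluoro, or with its hydrogen-bond acceptor, and a methoxy group or an amine on the same carbon would help to separate the two. They also leave open how the unsubstituted parent would compare with compound 2, and compound 1 cannot settle this, since it differs from compound 2 in more than one place.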